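The source may report more compounds than this note shows. Statements on the series, on what has been measured and on what is new or still open speak of the compounds shown alone.

Compound 1 `CN(C)/C(=N/CCCCn1nc(-c2ccccc2)ccc1=O)NC#N` carries a cyanoguanidine on the chain, and in a functional assay on the whole organism (stomach) with Rattus norvegicus as the target (on this read-out lower numbers stand for an effect already at smaller amounts and higher numbers for an effect only at larger amounts of compound), compound 1 gives 30.3 mg/kg. Compound 2 `C/N=C(/NC#N)NCCCCCn1nc(-c2ccccc2)ccc1=O` carries a differently methylated cyanoguanidine; in this assay compound 2 gives 100 mg/kg, and the step is a 3.3-fold higher number from compound 1 to compound 2 (0.52 log units; beyond the scatter). Compound 3 `C/N=C(/NC#N)N(C)CCCCn1nc(-c2ccccc2)ccc1=O` carries yet another methylation pattern on the cyanoguanidine. In this assay compound 3 reaches only the limit > 100 mg/kg, so no number stands for it. The step is accordingly an at least 3.3-fold higher number from compound 1 to compound 3 (0.51 log units; beyond the scatter), and a number no lower from compound 2 to compound 3 (the limit leaves the size open); one value of the three sits at the limit of > 100 mg/kg in this assay, at which 1 of the 3 values shown sits. Compound 4 `N#CNC(=N)NCCCCn1nc(-c2ccccc2)ccc1=O` differs from compound 3 by a group of 6 heavy atoms (2 carbon, 4 nitrogen; no ring) in place of a group of 8 heavy atoms (4 carbon, 4 nitrogen; no ring), on a saturated chain carbon, four bonds along the chain from an aromatic nitrogen, so that no methyl remains on the cyanoguanidine. The two steps that bear on this change point the same way: every rearrangement or addition of methyl from compound 1 gave a higher number, and compound 3 sits beyond the measurable range. Stripping the methyls runs against that direction. The number for compound 4 is therefore expected to drop back into the measurable range, the estimated step being an at least 2.5-fold lower number from compound 3 to compound 4 (0.39 log units; beyond the scatter) towards a lower number. Compound 4 is estimated at 40 mg/kg, with a range from 12 mg/kg to 120 mg/kg, while a return of only a limit cannot be excluded.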

Compound 4, dose for half-maximal effect: 77.2 mg/kg
The estimate for compound 4 lay 1.9-fold (0.29 log units) below the measured number, within the range that was stated.
By their numbers in this assay, from the lowest: compound 1; then compounds 4 and 2 (each within the scatter of the next).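

In this assay the cyanoguanidine without any methyl does not match the dimethylated group on the saturated chain carbon, the step being a 2.5-fold higher number from compound 1 to compound 4 (0.41 log units; beyond the scatter), so removing the methyls does not restore the lowest number in the set. Within the data shown here, compound 4 also stays close to compound 2, with a 1.3-fold lower number from compound 2 to compound 4 (0.11 log units; within the scatter), so this assay does not separate these two groups, and compound 1 remains the only compound whose steps to all the others are printed as beyond the scatter. Compound 3 is held only by a limit, so its step reads an at least 1.2-fold lower number from compound 3 to compound 4 (0.11 log units; that floor lies within the scatter), which on its own shows no separation from compound 4: the limit of > 100 mg/kg in this assay, at which 1 of the 4 values shown sits.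

From the compounds shown here alone, whether the dimethyl pattern of compound 1 is the feature that matters, or whether larger groups on the same nitrogen, such as two ethyl groups or a pyrrolidine, would lower the number further, remains open. Also open, going by these compounds, is how a urea or a thiourea in place of the cyanoguanidine, on the same chain and the same core, would read in this assay.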